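Lengthening the Chain on the Core by One Carbon

This account rests on a few compounds, and the source may have more. Where it says the series, first, only, none or still open, it means among the compounds named here.

Among the measured compounds shown here, compound 1 `CCn1nc(N[C@@H]2c3cc(C#N)ccc3OC(COC)(COC)[C@H]2O)ccc1=O` has the highest of the three numbers so far in an ADME assay on the whole organism (blood) for pharmacokinetics, with Canis familiaris (Canis lupus familiaris) as the target (on this read-out lower numbers stand for a shorter-lived compound and higher numbers for a longer-lived compound), where compound 1 gives 0.0867 h. Compound 2 `COCC1(COC)Oc2ccc(C#N)cc2[C@@H](Nc2ccc(=O)n(CC(=O)OC)n2)[C@@H]1O` gives 0.025 h, and compound 3 `COCC1(COC)Oc2ccc(C#N)cc2[C@@H](Nc2ccc(=O)n(CC#N)n2)[C@@H]1O` gives 0.0517 h. The measured steps ran a 3.5-fold lower number from compound 1 to compound 2 (0.54 log units; beyond the scatter) and a 1.7-fold lower number from compound 1 to compound 3 (0.22 log units; within the scatter), and between the other two a 2.1-fold higher number from compound 2 to compound 3 (0.32 log units; beyond the scatter). Compound 4 `CCCn1nc(N[C@@H]2c3cc(C#N)ccc3OC(COC)(COC)[C@H]2O)ccc1=O` differs from compound 1 by methyl in place of hydrogen on a saturated chain carbon, two bonds along the chain from an aromatic nitrogen. For the measured compounds named here, no measured step adds to the chain in this way; all three swap the methyl for another group, so they bear only loosely on this change, and no step beyond the scatter is expected in this assay. Compound 4 is therefore estimated at 0.08 h, within a range of 0.035 h to 0.18 h, an expected step of a 1.1-fold lower number from compound 1 to compound 4 (0.03 log units; within the scatter).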

Compound 4, half-life: 0.0633 h
Estimate against measurement, compound 4: 1.3-fold (0.10 log units) above, and the stated range covers the measured number.
By their numbers in this assay, from the lowest: compound 2; then compounds 3, 4 and 1 (each within the scatter of the next).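

In this assay the added methyl gives a 1.4-fold lower number from compound 1 to compound 4 (0.14 log units; within the scatter), so one more carbon on this chain moves the number by no more than the scatter. Ethyl in place of cyano gives a 1.2-fold higher number from compound 3 to compound 4 (0.09 log units; within the scatter) and ethyl in place of methoxycarbonyl gives a 2.5-fold higher number from compound 2 to compound 4 (0.40 log units; beyond the scatter), so at this position only the methoxycarbonyl group stands apart from the propyl chain. Nothing available here explains these numbers. As far as these compounds go, whether a longer chain, or an amine or a carboxylic acid on the chain, would hold the number in this range remains open.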